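Pyrimidin-5-yl in place of pyridin-3-yl: compound 3

A few compounds are considered here, and "the series" means these few. Any claim that something is new, unique, unknown or untested is made for them only; others in the source may bear on it.

In a functional assay on MCF7 cells (Homo sapiens) for inhibition, read by MTT assay (on this read-out lower numbers stand for stronger inhibition of growth and higher numbers for weaker inhibition of growth), compound 1 `CC1=C(/C=C/C(C)=C/C=C/C(C)=C\C(=O)NCc2ccc(F)cc2)C(C)(C)CCC1n1ccnc1` gives 1930 nM and compound 2 `CC1=C(/C=C/C(C)=C/C=C/C(C)=C\C(=O)Nc2ccccc2)C(C)(C)CC=C1c1cccnc1` gives 8320 nM. For the measured compounds named here, compound 2 stands highest of the two numbers so far; its nearest neighbour is compound 1, with the lower number, and that gap lies beyond the usual scatter. Compound 3 `CC1=C(/C=C/C(C)=C/C=C/C(C)=C\C(=O)Nc2ccccc2)C(C)(C)CC=C1c1cncnc1` differs from compound 2 in one place: pyrimidin-5-yl in place of pyridin-3-yl on a double-bonded ring carbon. Going by the values given here, no measured pair shows this change, so the step of a 1.2-fold higher number from compound 2 to compound 3 (0.08 log units; within the scatter) is expected to be small, near the scatter, leaning if anything toward weaker growth inhibition. Compound 3 is estimated at 10000 nM, within 4000 nM to 25000 nM.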

Compound 3, concentration for 50% growth inhibition: 7010 nM
Estimate against measurement, compound 3: 1.4-fold (0.15 log units) above; the range from low to high includes it.
By their numbers in this assay, from the lowest: compound 1; then compounds 3 and 2 (each within the scatter of the next).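

In this assay pyrimidin-5-yl in place of pyridin-3-yl on a double-bonded ring carbon gives a 1.2-fold lower number from compound 2 to compound 3 (0.07 log units; within the scatter) and so leaves the two compounds indistinguishable. On this core, then, the position takes a second ring nitrogen without a step beyond the scatter. No measurement on hand bears on why the two rings read alike.

Still open, going by these compounds, is whether this carbon accepts a group other than these two aromatic rings, such as an amine or a carboxylic acid. Also open, on these data alone, is whether the same exchange reads alike with a different amide substituent.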